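The source may report more compounds than this note shows. Statements on the series, on what has been measured and on what is new or still open speak of the compounds shown alone.

Measured compounds and their values:

Compound 1 `CC(C)(CNC(=O)c1ccccc1)CC1=C(O)C(=O)c2ccccc2C1=O`: 50500 nM
Compound 2 `CC(C)(CNC(=O)c1ccc2ccccc2c1O)CC1=C(O)C(=O)c2ccccc2C1=O`: 93700 nM
Compound 3 `COC1=C(CC(C)(C)CNC(=O)c2ccccc2)C(=O)c2ccccc2C1=O`: 12300 nM

In an ADME assay on Vero cells (Chlorocebus sabaeus) for cytotoxicity, read by fluorescence, with a stated time of 4 days (on this read-out lower numbers stand for stronger inhibition and higher numbers for weaker inhibition), compound 3 gives the lowest of the three numbers. Its nearest neighbour is compound 1, and the step of a 4.1-fold lower number from compound 1 to compound 3 (0.61 log units; beyond the scatter) shows a modest gain in inhibition from a methyl on an oxygen. Compound 2 shares the free hydroxyl of compound 1 but carries a larger amide group; in this assay compound 2 gives 93700 nM, while compound 1 gives 50500 nM, two values that lie close to one another.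

Compound 4 `COC1=C(CC(C)(C)CNC(=O)c2ccc3ccccc3c2)C(=O)c2ccccc2C1=O` keeps the methylated core of compound 3 and changes only the amide: naphthalen-2-yl in place of phenyl on a carbonyl carbon, on a carbonyl carbon whose other neighbour is an amide-type nitrogen. Among the measured compounds shown here, no measured step describes this exact change, since compound 2 differs from compound 1 in two places at once. With nothing directly comparable, the expectation is a small shift at most, a 1.2-fold lower number from compound 3 to compound 4 (0.09 log units; within the scatter), in either direction. Compound 4 is therefore estimated at 10000 nM, within a range from 3000 nM to 40000 nM.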

Compound 4, half-maximal inhibitory concentration: 36000 nM
For compound 4 the middle estimate is 3.6-fold (0.56 log units) below the measured one, and the stated range covers the measured number.
By their numbers in this assay, from the lowest: compound 3; then compounds 4, 1 and 2 (each within the scatter of the next, the first and the last beyond it).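

In this assay, among the compounds shown here, the only single change seen before this one sat on an oxygen of the core, so the effect of the group on the amide carbonyl carbon could not be read on its own. Here it can: with naphthalen-2-yl in place of phenyl, there is a 2.9-fold higher number from compound 3 to compound 4 (0.47 log units; beyond the scatter), a modest step towards weaker inhibition on the methylated core, so this position does affect the read-out. No measurement on hand explains why the second aromatic ring has this effect.

On these data alone, the same swap on the core with the free hydroxyl remains open, as compound 2 differs from compound 1 in two places. Also open, as far as these compounds go, is how a pyridine ring or a cyclohexyl group on this carbonyl carbon would compare with phenyl.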